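The source may report more compounds than this note shows. Statements on the series, on what has been measured and on what is new or still open speak of the compounds shown alone.

Compound 1 `O=C(Nc1ccc(Cl)cc1)c1nccc2ccccc12` was tested in a functional assay on NUGC-3 cells (Homo sapiens) for inhibition, read by sulforhodamine B assay, with a stated time of 48 h; on this read-out lower numbers stand for stronger inhibition of growth and higher numbers for weaker inhibition of growth. In this assay compound 1 gave > 10000 nM, which is a limit of the assay and not a number. Compound 2 `COc1ccccc1NC(=O)C1NCCc2ccccc21` was tested in the same way. In this assay compound 2 likewise gave > 10000 nM, again a limit rather than a number. Both measured values therefore belong to the limit of > 10000 nM in this assay, at which 2 of the 2 values shown sit, so compound 1 stands at that limit and nothing sets it apart from compound 2 on the numbers shown. Compound 3 `O=C(Nc1ccc(O)cc1)c1nccc2ccccc12` differs from compound 1 by hydroxy in place of chloro on an aromatic carbon, para to a large group. Within the data shown here, no step between measured compounds is known, so the data give no size for this change in this assay, and any move would only become visible if compound 3 reached a measurable number. Compound 3 is expected to give about 10000 nM, with a range from 3000 nM to 30000 nM. The expected step is a number no higher from compound 1 to compound 3 (the limit leaves the size open).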

Compound 3, concentration for 50% growth inhibition: > 10000 nM
Compound 3 was reported as a limit; the forecaster's own chance of this, stated with the estimate: 65%; the middle value sits exactly at the limit.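

In this assay compound 3 gave > 10000 nM, a limit and not a number. No step can be read between compound 1 and compound 3, because both stand at that limit: the limit of > 10000 nM in this assay, at which 3 of the 3 values shown sit.

The compounds shown leave open whether hydroxy and chloro differ at all in this assay.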